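The compounds below may be only part of what the source reports. "The series", "measured", "known", "first", "only" and "open" are said of these compounds alone.

Working notes on the series. In a functional assay on A2780 cells (Homo sapiens) for inhibition (a lower number here means a stronger inhibitor, a higher number a weaker inhibitor), compound 1 `CCNC(=O)c1noc(-c2cc(C(C)C)c(O)cc2O)c1-c1cc(CNC(C)=O)no1` gives "not determined" (no result reported). Among the measured compounds shown here, the only number so far therefore belongs to compound 2 `CCNC(=O)c1noc(-c2cc(C(C)C)c(O)cc2O)c1-c1cc(C(=O)OCC)no1`, at 9000 nM, and with nothing to compare it against, this value cannot yet be ranked. Compound 3 `CCNC(=O)c1noc(-c2cc(C(C)C)c(O)cc2O)c1-c1cc(C(=O)O)no1` differs from compound 2 by hydrogen in place of ethyl on an oxygen next to a carbonyl group, so ethoxycarbonyl becomes carboxy. For the measured compounds named here, no step between measured compounds is available to calibrate this change, so the expectation rests on the structural change alone and stays loose. A modest move towards weaker inhibition in this assay is expected, and the outcome may not clear the usual scatter. The estimated step of a 2.2-fold higher number from compound 2 to compound 3 (0.35 log units; beyond the scatter) reflects that expectation. Compound 3 is expected at 20000 nM, with an estimated range of 6000 nM to 70000 nM.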

Compound 3, half-maximal inhibitory concentration: 20000 nM
Estimate against measurement, compound 3: no gap at the digits printed, within the range that was stated.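

Among the compounds shown here, this is the first step readable at this position: hydrogen in place of ethyl on an oxygen next to a carbonyl group, turning ethoxycarbonyl into carboxy, gives a 2.2-fold higher number from compound 2 to compound 3 (0.35 log units; beyond the scatter) in this assay. The change therefore registers in this read-out, with the ethyl ester as the stronger inhibitor of this pair, and the step rests on this single pair of compounds on one shared core. Nothing measured here speaks to the reason for the shift.

Open, from the compounds shown here alone, is how far the trend extends along this position: whether a methyl ester or a longer chain on the same oxygen would match compound 2, and where a primary amide would fall relative to compound 3. Compound 1 has no number, so its side chain cannot yet be placed against either compound.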